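From a Methylphenyl Ether to Its Chlorinated Partner

The source may hold more compounds than are shown below. What is called first, only, known or untested is meant among the compounds shown, and "the series" means these compounds.

Of the compounds shown here, two have so far been measured in a physicochemical assay for lipophilicity, in phosphate buffer, measured as octanol-water partition; a higher number here means a more lipophilic compound, a lower number a more polar compound. Compound 1 `Cc1ccc(Oc2ccc(/C=N/n3c(C)nc4ccccc4c3=O)cc2)cc1` gives 4.32, the lower of the two numbers. Within the data shown here, compound 2 `Cc1ccc(Oc2ccc(/C=N/n3c(-c4ccccc4)nc4ccccc4c3=O)cc2)cc1` gives 6.29, and the step of a number 1.97 log units higher from compound 1 to compound 2 (beyond the scatter) is the only step measured. Compound 3 `Cc1cc(Oc2ccc(/C=N/n3c(C)nc4ccccc4c3=O)cc2)ccc1Cl` is not yet measured. It differs from compound 1 by 4-chloro-3-methylphenyl in place of 4-methylphenyl on an oxygen on an aromatic ring. Among the measured compounds shown here, no measured step bears on this change: the step from compound 1 to compound 2 exchanges a methyl for a phenyl on the shared core, a different group in a different place. The expectation therefore rests on the structural change alone, which keeps the phenoxy ring and adds one chlorine while moving the methyl. An increase beyond the scatter, smaller than the step to compound 2, is expected for compound 3, a number 0.68 log units higher from compound 1 to compound 3 (beyond the scatter). Compound 3 is estimated at 5, between 4.6 and 5.4.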

Compound 3, partition coefficient: 4.41
Compound 3: middle estimate off by 0.59 log units, on the high side, outside the stated range (below it).
By their numbers in this assay, from the lowest: compounds 1 and 3 (each within the scatter of the next); then compound 2.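

In this assay the exchange of 4-methylphenyl for 4-chloro-3-methylphenyl on an oxygen on an aromatic ring gives a number 0.09 log units higher from compound 1 to compound 3 (within the scatter) and so does not separate the two compounds. Among these compounds, this is the first measured change at this end of the molecule, and it stands apart from the change on the shared core, a number 1.97 log units higher from compound 1 to compound 2 (beyond the scatter) in a step that lies beyond the scatter, although the entering group here carries one more heavy atom, a chlorine. The data at hand offer no explanation for this result.

From the compounds shown here alone, it remains open how the added chlorine and the changed methyl placement would each read alone at this place, and whether the same exchange would read alike with phenyl on the core. Also open, going by these compounds, is whether an amine or a carboxylic acid on the phenoxy ring would move the number beyond the scatter.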